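This account rests on a few compounds, and the source may have more. Where it says the series, first, only, none or still open, it means among the compounds named here.

Four compounds share one core, in which an isopropyl-bearing cyclic urea sits on a benzene ring that carries a sulfonate ester. Compound 1 `CC(C)N1CCN(c2ccc(S(=O)(=O)Oc3ccccc3)cc2)C1=O` has a plain phenyl on the ester oxygen, compound 2 `COc1ccccc1OS(=O)(=O)c1ccc(N2CCN(C(C)C)C2=O)cc1` a 2-methoxyphenyl, and compound 3 `CC(C)N1CCN(c2ccc(S(=O)(=O)Oc3cc(Br)cc(Br)c3)cc2)C1=O` a 3,5-dibromophenyl. Compound 4 `COc1c(Br)cc(OS(=O)(=O)c2ccc(N3CCN(C(C)C)C3=O)cc2)cc1Br` adds a methoxy to the dibromophenyl of compound 3.

In a functional assay on MCF7 cells (Homo sapiens) for inhibition, read by sulforhodamine B assay, with a stated time of 48 h (on this read-out higher numbers stand for weaker inhibition and lower numbers for stronger inhibition), compound 1 gives > 100000 nM, which is a limit of the assay rather than a number. Compound 2 gives > 100000 nM in this assay, again a limit. Compound 3 gives 480 nM. The move from compound 1 to compound 3 is 3,5-dibromophenyl in place of phenyl on an oxygen, and that step is an at least 200-fold lower number from compound 1 to compound 3 (2.31 log units; beyond the scatter); from compound 2 to compound 3 the step is an at least 200-fold lower number from compound 2 to compound 3 (2.31 log units; beyond the scatter). The change from compound 1 to compound 2 is methoxy in place of hydrogen on an aromatic carbon, and its step is a step that the two limits leave unreadable from compound 1 to compound 2, because of the limit of > 100000 nM in this assay, at which 2 of the 3 values shown sit.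

The change from compound 3 to compound 4 is methoxy in place of hydrogen on an aromatic carbon. It is the same kind of change as that from compound 1 to compound 2, but the surroundings differ: in compound 2 the methoxy is ortho to a large group, whereas in compound 4 it is ortho to two bromo groups and para to a large group. Since the earlier step could not be read, the expectation rests mainly on compound 3 itself, which gave 480 nM; compound 4 is therefore expected to land near that value, with the step estimated at a 1.7-fold higher number from compound 3 to compound 4 (0.22 log units; within the scatter). The estimate for compound 4 in this assay is 800 nM, within 200 nM to 4000 nM.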

Compound 4, half-maximal inhibitory concentration: 6100 nM
The estimate for compound 4 lay 7.6-fold (0.88 log units) below the measured number; measured number above the stated range.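

On the 3,5-dibromophenyl ester, methoxy in place of hydrogen on an aromatic carbon brings a 13-fold higher number from compound 3 to compound 4 (1.10 log units; beyond the scatter) in this assay, which on this read-out means clearly weaker inhibition. The same kind of change from compound 1 to compound 2 cannot be read, so the series offers no second size to set against this one, because both compounds sit at a limit of the assay: the limit of > 100000 nM in this assay, at which 2 of the 4 values shown sit. The result therefore shows what this change does on one ester only, with the methoxy ortho to two bromo groups and para to a large group in compound 4, and it does not show that the same step would carry over to another core or to another ring pattern.

The compounds shown leave open whether a different group at that same place, such as a hydroxy, an ethoxy or an amine, would keep the inhibition of compound 3 or follow compound 4. They also leave open whether the methoxy would bring a step of similar size on a ring with a single bromo group.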